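This account rests on a few compounds, and the source may have more. Where it says the series, first, only, none or still open, it means among the compounds named here.

Working notes on the series. In an ADME assay on HepG2 cells (Homo sapiens) for cytotoxicity, read by MTT assay, with a stated time of 72 h (a higher number here means that more compound is tolerated, a lower number that less compound is tolerated), compound 1 (`O=[N+]([O-])c1cnc2c(Br)cc(Cl)cn12`) gives 16200 nM. Compound 2 (`CSCc1nc2c(Br)cc(Cl)cn2c1[N+](=O)[O-]`) reads > 15600 nM, which is a limit of the assay and not a number. Its position is therefore known only as that limit: the limit of > 15600 nM in this assay, at which 1 of the 2 values shown sits.

Compound 3 (`CS(=O)(=O)Cc1nc2c(Br)cc(Cl)cn2c1[N+](=O)[O-]`) keeps the shared core of compound 2 and changes only the side chain: methylsulfonyl in place of methylsulfanyl on a saturated chain carbon bound to an aromatic carbon. In words, this is methylsulfonyl in place of methylsulfanyl on a saturated chain carbon bound to an aromatic carbon.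

Among the measured compounds shown here, the only measured step that bears on this change is a step that the limit leaves unreadable from compound 1 to compound 2. For the measured compounds named here, it supplies no size to carry over, and no measured step involves the methylsulfonyl group. No step beyond the usual scatter is therefore expected in this assay, and no direction can be assigned. The expected change is a step that the limit leaves unreadable from compound 2 to compound 3. Compound 3 is estimated at 20000 nM, with an expected range of 10000 nM to 45000 nM. A report of only a limit would also be unsurprising, and the measurement should settle this.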

Compound 3, half-maximal cytotoxic concentration: 45000 nM
The estimate for compound 3 lay 2.3-fold (0.35 log units) below the measured number; low and high end bracket the measured number.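

In this assay, among the compounds shown here, adding the (methylsulfonyl)methyl side chain gives a 2.8-fold higher number from compound 1 to compound 3 (0.44 log units; beyond the scatter), the first readable step at this position. The earlier compounds shown here gave no size or direction for a substituent here, whereas compound 3 shows that this side chain can be carried with more compound tolerated than for the hydrogen of compound 1. Compound 2 is known only through a limit of the assay and not a number, so the steps that involve it cannot be read: the limit of > 15600 nM in this assay, at which 1 of the 3 values shown sits.

As far as these compounds go, whether methylsulfonyl and methylsulfanyl differ in this assay therefore stays open, as does whether the higher number of compound 3 belongs to the sulfonyl group or would appear with other substituents on the same saturated chain carbon. An amine or a carboxylic acid in place of methylsulfonyl, or a longer chain carrying the methylsulfonyl group, would show whether this step is specific to the group in compound 3.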